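Furan-2-yl in place of 4-methoxyphenyl on an oxime-bearing amide

The compounds below may be only part of what the source reports. "The series", "measured", "known", "first", "only" and "open" are said of these compounds alone.

This account concerns two measured compounds and one not yet measured, all tested in a functional assay on the whole organism (strain albino) for inhibition, with Rattus norvegicus as the target, read by paw edema, with stated times of 30 min and 1 h, at a dose of 100 mg/kg by the oral route; a higher number here means more inhibition at the dose given (going by the name of the read-out), a lower number less inhibition. Among the compounds with values here, compound 1, `CC(=O)c1ccc(OCC(=O)Nc2ccc(C(=O)/C=C/c3ccco3)cc2)cc1`, is the first of them; in this assay compound 1 gives 28%. Compound 2, `COc1ccc(/C=C/C(=O)c2ccc(NC(=O)COc3ccc(/C(C)=N\O)cc3)cc2)cc1`, is the second; in this assay compound 2 gives 33%. Within the data shown here, compound 2 therefore holds the higher of the two numbers so far, but the gap to compound 1 is within the usual scatter, so the two cannot be told apart.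

Compound 3, `C/C(=N/O)c1ccc(OCC(=O)Nc2ccc(C(=O)/C=C/c3ccco3)cc2)cc1`, differs from compound 2 in one place: furan-2-yl in place of 4-methoxyphenyl on a double-bonded chain carbon bound to a double-bonded chain carbon. Among the measured compounds shown here, no step between measured compounds shows the effect of exchanging these two groups on their own. The two numbers in hand lie within scatter of each other, and nothing in them points in either direction.

The account therefore expects no step beyond the scatter, so that a number 3 percentage points lower from compound 2 to compound 3 (within the scatter) is estimated to be small. Compound 3 is expected to give 30% in this assay, with a range from 18% to 42%.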

Compound 3, a percentage reported as inhibition, in the whole organism at one dose (the size of the read-out at that dose, not a potency): 36%
Compound 3: middle estimate off by 6 percentage points, on the low side; low and high end bracket the measured number.
By their numbers in this assay, from the lowest: compounds 1, 2 and 3 (each within the scatter of the next).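

In this assay, the exchange of 4-methoxyphenyl for furan-2-yl on a double-bonded chain carbon bound to a double-bonded chain carbon now has a step of its own, a number 3 percentage points higher from compound 2 to compound 3 (within the scatter), so with the oxime-bearing side held constant, this place accepts the five-membered aromatic ring without a change that can be told from the scatter. Within the data shown here, compound 3 also gives the first reading of the other end of the molecule: with furan-2-yl held constant, the group of 4 heavy atoms in place of the group of 3 heavy atoms on an aromatic carbon gives a number 8 percentage points higher from compound 1 to compound 3 (within the scatter), so at this single oral dose neither exchange separates the compounds it joins. Nothing available here bears on why either step is this small.

Still open, on these data alone, is whether either place would respond to a different group, such as pyridin-3-yl or thiophen-2-yl in place of furan-2-yl, or a carboxylic acid or an amine in place of the oxime. As far as these compounds go, all three compounds are read at one dose, so how they would compare at another dose also remains open.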